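This account rests on a few compounds, and the source may have more. Where it says the series, first, only, none or still open, it means among the compounds named here.

Measured so far:
- Compound 1, `c1ccc(Oc2ccc3c(NCCCNCc4ccco4)ccnc3c2)cc1`: 14500 nM
- Compound 2, `CCC(CC)c1ccc2c(NCCCNCc3ccco3)ccnc2c1`: 4200 nM
- Compound 3, `c1ccc(Cc2ccc3c(NCCCNCc4ccco4)ccnc3c2)cc1`: 4200 nM

In a physicochemical assay for solubility, with a stated time of 18 h, at pH 7.4 (a lower number here means a less soluble compound, a higher number a more soluble compound), compound 3 stands level with compound 2 at the digits given, and these two are together the lowest of the three numbers. The only larger gap is to compound 1: a 3.5-fold lower number from compound 1 to compound 3 (0.54 log units; beyond the scatter), and likewise a 3.5-fold lower number from compound 1 to compound 2 (0.54 log units; beyond the scatter). Between compounds 2 and 3 the record is no change at the digits printed from compound 2 to compound 3 (within the scatter), so swapping pentan-3-yl for benzyl on that aromatic carbon leaves this assay unmoved.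

Compound 4, `COc1ccc(-c2ccc3c(NCCCNCc4ccco4)ccnc3c2)cc1`, has not yet been measured. It differs from compound 3 in one place: 4-methoxyphenyl in place of benzyl on an aromatic carbon.

Within the data shown here, no measured step covers an aryl group joined directly to the core, so none bears on this change closely. The steps that exist show that replacing phenoxy with either an alkyl or a benzyl group at this position lowers the number by a modest margin, while the exchange of those two among themselves does not move it. With nothing pointing to a shift beyond the scatter, the expectation for compound 4 is a number close to that of compound 3, within the scatter: a 1.2-fold lower number from compound 3 to compound 4 (0.08 log units; within the scatter) is the estimated step. The estimate for compound 4 in this assay is 3500 nM, with a range from 1200 nM to 10000 nM.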

Compound 4, solubility: 32000 nM
For compound 4 the middle estimate is 9.1-fold (0.96 log units) below the measured one; the measured number lies above the stated range.
By their numbers in this assay, from the lowest: compounds 2 and 3 (each within the scatter of the next); then compound 1; then compound 4.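

In this assay, among these compounds, the position carries a wider span than the earlier compounds showed: with 4-methoxyphenyl in place of benzyl there is a 7.6-fold higher number from compound 3 to compound 4 (0.88 log units; beyond the scatter), and with 4-methoxyphenyl in place of pentan-3-yl there is a 7.6-fold higher number from compound 2 to compound 4 (0.88 log units; beyond the scatter), so the flat exchange between pentan-3-yl and benzyl does not extend to this aryl group joined directly to the core. The same group also moves past phenoxy, with a 2.2-fold higher number from compound 1 to compound 4 (0.34 log units; beyond the scatter), which places compound 4 highest of the four and shows that the top of the series is not set by phenoxy. The entering group counts one hydrogen-bond acceptor where benzyl counts none, but that is only a count, and nothing on record explains these steps.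

The compounds shown leave open whether the higher number goes with the directly joined aromatic ring or with its methoxy group, a question that a plain phenyl group on the same carbon would address. As far as these compounds go, how an amine or a carboxylic acid on that ring would read in this assay also stays open.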